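One Methyl Less: From Compound 1 to Compound 3

This account rests on a few compounds, and the source may have more. Where it says the series, first, only, none or still open, it means among the compounds named here.

Of the compounds shown here, two have so far been tested in a functional assay on A-431 cells (Homo sapiens) for cytotoxicity, read by MTT assay, with a stated time of 72 h, tested at 100 uM; a lower number here means less inhibition of growth, a higher number more inhibition of growth at the concentration tested. Compound 1 `Cc1ccnc(/C(N)=N/NC(=S)N2CCCCCC2)c1` gives 71% in this assay. Compound 2 `N/C(=N\NC(=S)N1CCN(c2ccccn2)CC1)c1ccc(F)cn1` gives 77.1% in this assay. These two numbers lie within the usual scatter of each other, so neither compound can be said to inhibit growth more than the other; compound 1 simply holds the lower of the two numbers, with compound 2 close by.

Compound 3 `N/C(=N\NC(=S)N1CCCCCC1)c1ccccn1` is not yet measured. It differs from compound 1 in a single place: hydrogen in place of methyl on an aromatic carbon. Within the data shown here, no pair of measured compounds differs in just one place, so there is no measured step to show what removing one carbon from the edge of the shared core does here. Given that the change is small and that compound 1 gives 71%, the expected step of a number 3 percentage points lower from compound 1 to compound 3 (within the scatter) is none beyond the scatter. On that basis compound 3 is expected to give about 68% in this assay, with a likely range from 50% to 85%.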

Compound 3, percent growth inhibition at one concentration: 77.5%
Estimate against measurement, compound 3: 9.5 percentage points below; measured number inside the range.
By their numbers in this assay, from the lowest: compounds 1, 2 and 3 (each within the scatter of the next).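

Among these compounds, compound 1 and compound 3 form the first measured pair here that differs in only one place, so this position now has a real step in this assay: hydrogen in place of methyl gives a number 6.5 percentage points higher from compound 1 to compound 3 (within the scatter) on this scale. At this aromatic carbon, opposite the ring nitrogen, the methyl can therefore be left out without the number moving beyond the usual scatter, which means this one carbon is not required for the growth inhibition seen at the concentration tested. No measurement shown here offers an explanation for the size of this step.

On these data alone, this single step covers only methyl and hydrogen, so it remains open whether a larger or quite different group on the same carbon, such as a longer alkyl chain, a methoxy group, an amine or a carboxylic acid, would also leave the number within the scatter. As far as these compounds go, since each number comes from one concentration, it also remains open whether compound 1 and compound 3 would still give numbers this close at lower concentrations.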